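The source may report more compounds than this note shows. Statements on the series, on what has been measured and on what is new or still open speak of the compounds shown alone.

Of the compounds shown here, two have been measured in a functional assay on PC-3 cells (Homo sapiens) for cytotoxicity, read by MTT assay, with a stated time of 72 h; a lower number here means that less compound is tolerated, a higher number that more compound is tolerated. Compound 1, with the structure `CS/C(=N\C(=O)c1cc2ccccc2s1)NC(=O)c1cc2ccccc2s1`, gives 72600 nM in this assay. Compound 2, with the structure `C[Se]/C(=N\C(=O)c1cccs1)NC(=O)c1cccs1`, reaches only the limit of the assay in this assay, reported as > 100000 nM, which is not a number but the top of the range the assay can report. That is where compound 2 stands: at the limit of > 100000 nM in this assay, at which 1 of the 2 values shown sits, so its true value could lie anywhere beyond that point. Compound 3, with the structure `CS/C(=N\C(=O)c1cccs1)NC(=O)c1cccs1`, has not yet been measured in this assay. It differs from compound 2 by a group of 2 heavy atoms (1 carbon, 1 sulfur; no ring) in place of a group of 2 heavy atoms (1 carbon, 1 selenium; no ring), on a carbon with a double bond to nitrogen. For the measured compounds named here, no step between two measured compounds tells how much such a change shifts the read-out, and compound 1 carries a different core, so its value of 72600 nM gives only a loose hint that a methylsulfanyl compound can sit near the upper end of the scale. The expected step from compound 2 to compound 3 is therefore a number no higher from compound 2 to compound 3 (the limit leaves the size open), which is no more than the usual scatter. Compound 3 is estimated to give 100000 nM in this assay, within the range of 50000 nM to 300000 nM, quite possibly again only as a limit.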

Compound 3, concentration lethal to 50% of the cells: > 100000 nM
Compound 3 was reported as a limit (the forecaster's own chance of this, stated with the estimate: 60%); the middle value lies on the limit itself.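

No step can be read from compound 2 to compound 3, because both are reported only as a limit of the assay, not as a number: the limit of > 100000 nM in this assay, at which 2 of the 3 values shown sit.

The compounds shown leave open whether methylsulfanyl in place of the group holding selenium changes the read-out at all, and how far past that limit the true values of compound 2 and compound 3 lie.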